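The source may report more compounds than this note shows. Statements on the series, on what has been measured and on what is new or still open speak of the compounds shown alone.

In a functional assay on MCF7 cells (Homo sapiens) for inhibition, read by MTT assay, with a stated time of 72 h, tested at 30 uM (a higher number here means more inhibition of growth at the concentration tested, a lower number less inhibition of growth), compound 3 `C=CCc1ccc(OCc2cn(-c3ccccc3CO)nn2)c(O)c1` gives 34.5%, within the scatter of compound 1 `C=CCc1ccc(OCc2cn(-c3cccc([N+](=O)[O-])c3)nn2)c(O)c1` at 42.3%. Compound 2 `C=CCc1ccc(OCc2cn(-c3ccccc3Cl)nn2)c(O)c1` gives 58.3%. Among the measured compounds shown here, the only measured step reads a number 23.8 percentage points lower from compound 2 to compound 3 (beyond the scatter), with hydroxymethyl in place of chloro on an aromatic carbon.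

The next structure is compound 4 `C=CCc1ccc(OCc2cn(-c3cccc(C#N)c3)nn2)c(O)c1`, with 3-cyanophenyl in place of 2-(hydroxymethyl)phenyl on an aromatic nitrogen. The measured step bears on this only in part: compound 4 also lacks the hydroxymethyl group, but it carries a nitrile, not a chloro group. With a nitro group where compound 4 has the nitrile, the closer guide is compound 1 at 42.3%. A small rise is therefore expected, well short of the measured step and perhaps none beyond the scatter. The estimated change is a number 8.5 percentage points higher from compound 3 to compound 4 (within the scatter). The estimated value for compound 4 is 43%, with an expected range from 29% to 58%.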

Compound 4, percent growth inhibition at one concentration: 31.9%
The estimate for compound 4 lay 11.1 percentage points above the measured number; low and high end bracket the measured number.
By their numbers in this assay, from the lowest: compounds 4, 3 and 1 (each within the scatter of the next, the first and the last beyond it); then compound 2.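

In this assay, the step to 3-cyanophenyl reads a number 2.6 percentage points lower from compound 3 to compound 4 (within the scatter) and does not separate it from 2-(hydroxymethyl)phenyl, whereas the step from 2-chlorophenyl reads a number 26.4 percentage points lower from compound 2 to compound 4 (beyond the scatter) and keeps the chloro compound apart. Cyano in place of nitro reads a number 10.4 percentage points lower from compound 1 to compound 4 (beyond the scatter) and shows that one group exchanged on this aryl ring, with the ring's attachment to the aromatic nitrogen unchanged, can register in this read-out. No supporting measurement is available to explain these differences.

As far as these compounds go, compound 2 and compound 4 differ in both the group and where it sits on the ring, so the contribution of each remains open. From the compounds shown here alone, how an amine or a carboxylic acid on this aryl ring would compare with chloro, nitrile and nitro is also open.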